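The source may report more compounds than this note shows. Statements on the series, on what has been measured and on what is new or still open speak of the compounds shown alone.

Compound 1 `CC(=O)N(C)C(C)C#CCn1ccnc1` is the starting point of this small series. In a functional assay on the whole organism for antagonist activity, with Mus musculus as the target (a higher number here means that more compound is needed for the effect, a lower number that less compound is needed), compound 1 gives only a limit of the assay, > 100 mg/kg, and not a number. Compound 2 `CC(=O)N(C)C(C)C#CCn1cncc1C` carries one change against compound 1, (methyl in place of hydrogen on an aromatic carbon), and in this assay compound 2 gives 3.7 mg/kg. The step of an at least 27-fold lower number from compound 1 to compound 2 (1.43 log units; beyond the scatter) is therefore the one clear movement measured so far.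

Compound 3 `O=C1NCCN1CC#CCn1ccnc1` has a different core, and how it differs from compound 1 is not broken down here. In this assay compound 3 gives only a limit of the assay, > 100 mg/kg, not a number. Within the data shown here, that this is the limit of > 100 mg/kg in this assay, at which 2 of the 3 values shown sit, means the series so far rests on one measured number and two limits.

Compound 4 `Cc1cncn1CC#CCN1CCNC1=O` is not yet measured. It stands to compound 3 as compound 2 stands to compound 1, by the change (methyl in place of hydrogen on an aromatic carbon), which is the same change, on the same place of the same kind of ring, as that from compound 1 to compound 2. Since compound 3 sits at the same limit as compound 1 in this assay, one expects the step from compound 3 to compound 4 to be an at least 12-fold lower number from compound 3 to compound 4 (1.09 log units; beyond the scatter), resting on the step of an at least 27-fold lower number from compound 1 to compound 2 (1.43 log units; beyond the scatter), though on the other core the size carries real uncertainty. On this basis compound 4 is estimated at 8 mg/kg in this assay, with a range from 2 mg/kg to 60 mg/kg.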

Compound 4, dose for half-maximal effect: 66 mg/kg
Beside the measured number, compound 4's estimate is 8.3-fold (0.92 log units) below it, outside the stated range (above it).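

Carried to the other core, methyl in place of hydrogen on an aromatic carbon gives, in this assay, an at least 1.5-fold lower number from compound 3 to compound 4 (0.18 log units; that floor lies within the scatter). Going by these compounds, compound 3, the starting point of this step, gives > 100 mg/kg, which is a limit of the assay and not a number, so the true size of the step stays unknown and it cannot be said to go beyond the scatter. The change does yield a measured number on both cores, but this does not show that it acts to the same extent on the two, since each step starts from a limit: the same change on two cores in this assay, an at least 27-fold lower number (1.43 log units; beyond the scatter) from compound 1 to compound 2 and an at least 1.5-fold lower number (0.18 log units; that floor lies within the scatter) from compound 3 to compound 4; the limit leaves it open whether they differ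

The compounds shown carry only methyl at this place on the ring, so it remains open whether ethyl, chlorine or a longer chain there would give a measured number on either core. Also open is where compound 1 and compound 3 really lie, and with that the true size of both steps, which rests on this: the limit of > 100 mg/kg in this assay, at which 2 of the 4 values shown sit.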